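Swapping a fluorinated aryl for a methoxypyridine

A few compounds are considered here, and "the series" means these few. Any claim that something is new, unique, unknown or untested is made for them only; others in the source may bear on it.

Compound 1 `COc1ccc(C#Cc2ccc(C(=O)N3CCC[C@@H](CO)C3)cc2)c(F)c1` is one of three compounds tested in a functional assay on TREX cells for negative allosteric modulation of metabotropic glutamate receptor 3 (Rattus norvegicus), read by calcium flux, with a stated time of 2.5 min; a lower number here means a stronger inhibitor, a higher number a weaker inhibitor. For compound 1 the assay gives only a limit, > 10000 nM, so no single number is known for it. Compound 3 `CC(C)Oc1ccc(C#Cc2ccc(C(=O)N3CCC[C@@H](CO)C3)cc2)cc1` likewise returns only a limit, > 10000 nM. Compound 2 `COc1ccc(C#Cc2ccc(C(=O)N3CCC[C@@H](O)C3)cc2F)cc1`, which carries a different pattern of substituents, is the only one of the three with a measured number, giving 456 nM; 457 nM (2 entries) in this assay; its repeated entries agree closely, as the several entries of compound 2 in this assay, 456 nM; 457 nM (2 entries) shows. Two of the three values therefore sit at the limit, as the limit of > 10000 nM in this assay, at which 2 of the 3 values shown sit, states, and compound 1 stands among them, at the weak end of what this set shows.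

Compound 4 `COc1ccc(C#Cc2ccc(C(=O)N3CCC[C@@H](CO)C3)cc2)cn1` has not yet been measured. It differs from compound 1 in one place: 6-methoxypyridin-3-yl in place of 2-fluoro-4-methoxyphenyl on a triple-bonded carbon. For the measured compounds named here, no measured pair in this set isolates this change, so no step can be read off for it. Compound 1 sits at the limit, > 10000 nM. Compound 3 likewise sits at the limit, > 10000 nM. With both of them there, compound 4 is expected to stay near the same region, and the step of a number no higher from compound 1 to compound 4 (the limit leaves the size open) is expected to be none beyond the scatter. The estimate for compound 4 is 10000 nM, within a range from 2500 nM to 40000 nM, with a fair chance that the assay again reports only a limit.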

Compound 4, half-maximal inhibitory concentration: > 10000 nM
Compound 4: no number, only a limit; the forecaster's own chance of this, stated with the estimate: 65%; the middle value sits exactly at the limit.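

For the compounds shown here, compound 1 and compound 4 each return only a limit rather than a number, so no step between them can be read. The compounds shown leave open whether 6-methoxypyridin-3-yl in place of 2-fluoro-4-methoxyphenyl changes the inhibition at all, and how weak compound 1 and compound 4 actually are.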